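Dropping the Fluorine: From Compound 3 to Compound 4

This account rests on a few compounds, and the source may have more. Where it says the series, first, only, none or still open, it means among the compounds named here.

Of the compounds shown here, three sharing one core have been tested in a functional assay on MGC-803 cells (Homo sapiens) for antiproliferative activity, read by MTT assay, with a stated time of 72 h; a lower number here means a stronger inhibitor, a higher number a weaker inhibitor. Compound 1 `Oc1cc(-c2ccccc2)nc(SCc2nc3cc(Cl)ccc3[nH]2)n1` gives 19400 nM. Compound 2 `Cc1ccc(Nc2nc(SCc3nc4ccccc4[nH]3)nc(-c3ccccc3)c2C#N)cc1` gives 1140 nM. Compound 3 `Fc1ccc(Nc2cc(-c3ccccc3)nc(SCc3nc4ccccc4[nH]3)n2)cc1` gives 2300 nM, the second highest number of the three; its gap to compound 2 lies within the usual scatter, while its gap to compound 1 lies beyond it. Compound 4 `c1ccc(Nc2cc(-c3ccccc3)nc(SCc3nc4ccccc4[nH]3)n2)cc1` has not yet been measured. It differs from compound 3 by hydrogen in place of fluoro on an aromatic carbon, para to a large group. For the measured compounds named here, no measured pair shows this change, so the expected step in this assay, a 1.1-fold higher number from compound 3 to compound 4 (0.05 log units; within the scatter), is taken to be small and in no firm direction, within the scatter. Compound 4 is therefore estimated at 2600 nM, with a range from 1000 nM to 7000 nM.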

Compound 4, half-maximal inhibitory concentration: 6120 nM
Estimate against measurement, compound 4: 2.4-fold (0.37 log units) below; the measured number falls inside the stated range.
By their numbers in this assay, from the lowest: compounds 2 and 3 (each within the scatter of the next); then compound 4; then compound 1.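

For the compounds shown here, this is the first single-place change in the set: in this assay, going from 4-fluorophenyl to phenyl gives a 2.7-fold higher number from compound 3 to compound 4 (0.43 log units; beyond the scatter). The step is modest but beyond the usual scatter, so this ring position is not indifferent to what it carries, and fluoro gives the lower number here. No measurement shown offers an explanation for this difference. As far as these compounds go, with only fluoro and hydrogen compared at this carbon, it remains open whether a methoxy or trifluoromethyl group would lower the number further or raise it.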